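Clearance notes: chloro in place of fluoro

A few compounds are considered here, and "the series" means these few. Any claim that something is new, unique, unknown or untested is made for them only; others in the source may bear on it.

Measured in an in vitro ADME assay on microsomes from liver (Mus musculus) for pharmacokinetics, read by LC-MS, with a stated time of 10 min, tested at 1 uM (a higher number here means faster removal of the compound, a lower number slower removal), so far
- compound 1 `Cc1cccc(NC(=O)[C@H]2CN(C)C[C@@H]2c2ccc(/C=C/C(=O)Nc3ccccc3N)cc2)c1` (74 mL/min/kg)
- compound 2 `CN1C[C@H](C(=O)Nc2ccc(F)cc2F)[C@@H](c2ccc(/C=C/C(=O)Nc3ccccc3N)cc2)C1` (27 mL/min/kg)

Still to be measured
- compound 3 `CN1C[C@H](C(=O)Nc2ccc(Cl)cc2F)[C@@H](c2ccc(/C=C/C(=O)Nc3ccccc3N)cc2)C1`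

Compound 2 holds the lower of the two measured numbers. The change to compound 3 is chloro in place of fluoro on an aromatic carbon on an aromatic carbon, meta to a fluoro group and para to a large group. Going by the values given here, one measured step bears on this, and only loosely. It is a 2.7-fold lower number from compound 1 to compound 2 (0.44 log units; beyond the scatter), a modest step, with 2,4-difluorophenyl in place of 3-methylphenyl on an amide-type nitrogen, so a change in this group has moved the number once. Among the compounds with values here, no measured step exchanges fluoro for chloro. In this assay the expected step is a 1.3-fold higher number from compound 2 to compound 3 (0.11 log units; within the scatter), a small rise that may stay within the scatter. For compound 3 the estimated clearance is 35 mL/min/kg (expected range 18 mL/min/kg to 65 mL/min/kg).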

Compound 3, clearance: 43 mL/min/kg
The estimate for compound 3 lay 1.2-fold (0.09 log units) below the measured number; low and high end bracket the measured number.
By their numbers in this assay, from the lowest: compounds 2, 3 and 1 (each within the scatter of the next, the first and the last beyond it).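

In this assay, chloro in place of fluoro, para to a large group, gives a 1.6-fold higher number from compound 2 to compound 3 (0.20 log units; within the scatter) and so does not separate the two halogens at this position. Going by these compounds alone, replacing 3-methylphenyl with 4-chloro-2-fluorophenyl gives a 1.7-fold lower number from compound 1 to compound 3 (0.24 log units; within the scatter) and also stays within the scatter, whereas the 2,4-difluorophenyl change gives a 2.7-fold lower number from compound 1 to compound 2 (0.44 log units; beyond the scatter) and is the only one of the three steps that clears it, leaving compound 3 unresolved from both compound 1 and compound 2. No accompanying measurement bears on the reason for any of these steps.

Still open, from the compounds shown here alone, is how a nitrile, a methoxy group or an amine in place of the chloro would read in this assay. Within the data shown here, also open is what the fluoro group kept in compound 2 and compound 3 contributes, since no step here exchanges it alone.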